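The source may report more compounds than this note shows. Statements on the series, on what has been measured and on what is new or still open speak of the compounds shown alone.

Compound 1 `CCOC(=O)c1c(CN(CC)Cc2ccccc2)nc2ccccc2c1-c1ccccc1` — in an assay on brain with Translocator protein (Rattus norvegicus) as the target (on this read-out higher numbers stand for weaker inhibition and lower numbers for stronger inhibition), compound 1 gives 700 nM
Compound 2 `CCN(Cc1ccccc1)Cc1nc2ccccc2c(-c2ccccc2)c1C(=O)N(CC)CC` — compound 2 gives 373 nM
Compound 3 `CCCN(CCC)C(=O)c1c(CN(CC)Cc2ccccc2)nc2ccccc2c1-c1ccccc1` — compound 3 gives 456 nM

Among these three numbers compound 3 sits second highest. Its nearest neighbour is compound 2, with a 1.2-fold higher number from compound 2 to compound 3 (0.09 log units; within the scatter); its furthest is compound 1, with a 1.5-fold lower number from compound 1 to compound 3 (0.19 log units; within the scatter). Both gaps are within the scatter, so the three compounds cannot be told apart on this read-out.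

Compound 4 `CCN(Cc1ccccc1)Cc1nc2ccccc2c(-c2ccccc2)c1C(=O)N(C)c1ccc(Cl)cc1` differs from compound 3 in one place: (4-chlorophenyl)(methyl)amino in place of dipropylamino on a carbonyl carbon. All three measured steps concern the same carbonyl carbon, and each of them, a 1.9-fold lower number from compound 1 to compound 2 (0.27 log units; within the scatter), a 1.5-fold lower number from compound 1 to compound 3 (0.19 log units; within the scatter) and a 1.2-fold higher number from compound 2 to compound 3 (0.09 log units; within the scatter), stayed within the scatter. None of them, however, brings an aromatic ring onto that carbonyl, so the new change reaches beyond what the measured steps cover. The expectation is therefore a step of no clear direction, most likely within the scatter, as a 1.1-fold lower number from compound 3 to compound 4 (0.06 log units; within the scatter), with a wide range allowed. Compound 4 is estimated at 400 nM, between 120 nM and 1300 nM.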

Compound 4, half-maximal inhibitory concentration: 2480 nM
Beside the measured number, compound 4's estimate is 6.2-fold (0.79 log units) below it; measured number above the stated range.
By their numbers in this assay, from the lowest: compounds 2, 3 and 1 (each within the scatter of the next); then compound 4.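

Earlier swaps among ethoxy, diethylamino and dipropylamino on this carbonyl carbon all stayed within the scatter, which made the position look tolerant. In this assay, among these compounds, (4-chlorophenyl)(methyl)amino is the first group there to move the number beyond the scatter, and it does so against all three earlier groups (a 5.4-fold higher number from compound 3 to compound 4 (0.74 log units; beyond the scatter)) (a 6.6-fold higher number from compound 2 to compound 4 (0.82 log units; beyond the scatter)) (a 3.5-fold higher number from compound 1 to compound 4 (0.55 log units; beyond the scatter)), each time towards weaker inhibition. Nothing available explains this loss. The compounds shown leave open which part of the entering group carries the step: the six-membered aromatic ring, the chlorine or the methyl on the nitrogen. A phenyl(methyl)amino group without the chlorine, or a 4-chlorophenylamino group without the methyl, would help to separate these parts.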